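This account rests on a few compounds, and the source may have more. Where it says the series, first, only, none or still open, it means among the compounds named here.

Three members of the series carry a number in a functional assay on the whole organism (strain Swiss) with Mus musculus as the target, in the maximal electroshock model, with a stated time of 1 h, at a dose of 100 mg/kg by the intraperitoneal route; on this read-out higher numbers stand for a stronger effect at the one dose given and lower numbers for a weaker effect. Compound 1 `COCC(C(=O)N1CCN(c2cccc(C(F)(F)F)c2)CC1)N1C(=O)CCC1=O` gives 50%. Compound 2 `CC(C(=O)N1CCN(c2ccc(Cl)cc2)CC1)N1C(=O)CCC1=O` gives 0%, and compound 3 `CCC(C(=O)N1CCN(c2cccc(F)c2)CC1)N1C(=O)CCC1=O` gives 0%. Compound 2 therefore stands level with compound 3 at the digits shown, the two together forming the lowest of the three numbers, while compound 1 lies beyond the scatter above compound 2. Going by the values given here, no pair of the measured compounds differs in one place only, so no single step can be read off from them. Compound 4 `Cc1cccc(N2CCN(C(=O)C(C)N3C(=O)CCC3=O)CC2)c1` is not yet tested in this assay. It differs from compound 2 as follows: 3-methylphenyl in place of 4-chlorophenyl on an amine nitrogen in a ring. Compound 3 is level with compound 2. Compound 1 gives 50%, but it differs from compound 2 in several places, so which of its differences carries that gap cannot be told. The step of a number 10 percentage points higher from compound 2 to compound 4 (within the scatter) is expected to be modest, upward if anything, and may not exceed the scatter. Compound 4 is estimated at 10%, within a range from 0% to 40%.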

Compound 4, a percentage reported as activity, at one dose (the size of the read-out at that dose, not a potency): 0%
Compound 4: middle estimate off by 10 percentage points, on the high side; the measured number falls inside the stated range.
By their numbers in this assay, from the lowest: compounds 2, 3 and 4 (each within the scatter of the next); then compound 1.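

In this assay, going by these compounds alone, 3-methylphenyl in place of 4-chlorophenyl on an amine nitrogen in a ring gives no change at the digits printed from compound 2 to compound 4 (within the scatter), the first step that can be read at this position. With the rest of the structure held, this exchange of one substituted phenyl for another, which changes both the substituent and its place on the phenyl ring, leaves the read-out where it stood at the one dose given. Nothing available explains this result.

Still open, going by these compounds, is which of its several differences from the other compounds carries the value of compound 1, 50%: the trifluoromethyl group on the phenyl ring, the methoxymethyl side chain, or both together. Also open, on these data alone, is how a nitrile or a carboxylic acid on that phenyl ring would read on the core of compound 2.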